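Trifluoromethoxy for Fluoro in a Series at the Limit

This account rests on a few compounds, and the source may have more. Where it says the series, first, only, none or still open, it means among the compounds named here.

Compound 1 `Oc1ccc(-c2cc(-c3ccccc3F)cc(-c3ccccc3O)n2)cc1` is the reference point. In a functional assay on HeLa cells (Homo sapiens) for inhibition (on this read-out higher numbers stand for weaker inhibition and lower numbers for stronger inhibition), compound 1 gives > 50000 nM, which is a limit of the assay rather than a number. The step that the two limits leave unreadable from compound 1 to compound 2 exchanges 3-fluorophenyl for 2-fluorophenyl on an aromatic carbon, giving compound 2 `Oc1ccc(-c2cc(-c3cccc(F)c3)cc(-c3ccccc3O)n2)cc1`. In this assay compound 2 gives > 50000 nM, again a limit. The step that the two limits leave unreadable from compound 1 to compound 3 moves the hydroxy group on one of the phenyl rings, giving compound 3 `Oc1ccc(-c2cc(-c3ccccc3F)cc(-c3ccc(O)cc3)n2)cc1`. In this assay compound 3 gives > 50000 nM, also a limit. Neither step can be sized because the limit of > 50000 nM in this assay, at which 3 of the 3 values shown sit, hides any movement. Compound 4 `Oc1ccc(-c2cc(-c3ccccc3OC(F)(F)F)cc(-c3ccccc3O)n2)cc1` differs from compound 1 by trifluoromethoxy in place of fluoro on an aromatic carbon. For the measured compounds named here, no measured step bears on this exchange, so compound 4 is expected to remain at the limit, with a step that the limit leaves unreadable from compound 1 to compound 4 meaning no readable change. The estimate for compound 4 is 60000 nM, expected between 20000 nM and 200000 nM.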

Compound 4, half-maximal inhibitory concentration: 6010 nM
Estimate against measurement, compound 4: 10-fold (1.00 log units) above; the measured number lies below the stated range.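

Placing trifluoromethoxy in place of fluoro on this aromatic carbon, ortho to a large group, gives the first readable change in this assay: an at least 8.3-fold lower number from compound 1 to compound 4 (0.92 log units; beyond the scatter). This gives only a minimum size for the step, but it shows that the number responds to the group at this position. The earlier steps to compound 2 and compound 3 cannot be read, so they could not show this: the limit of > 50000 nM in this assay, at which 3 of the 4 values shown sit.

As far as these compounds go, whether methoxy or trifluoromethyl at this position would give a similar step remains open. So does whether trifluoromethoxy would give a readable step on the core of compound 3.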